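A few compounds are considered here, and "the series" means these few. Any claim that something is new, unique, unknown or untested is made for them only; others in the source may bear on it.

Of the compounds shown here, three that share one core have been measured in a functional assay on MGC-803 cells (Homo sapiens) for antiproliferative activity, read by CCK-8 assay, with a stated time of 72 h, tested at 8 uM; a higher number here means a stronger effect of the compound at the concentration tested, a lower number a weaker effect. Compound 1 `Nc1ccccc1NC(=O)c1ccc(CSC(=S)N2CCN(Cc3ccncc3)CC2)cc1` gives 79.3% in this assay, and compound 2 `CN1CCN(C(=S)SCc2ccc(C(=O)Nc3ccccc3N)cc2)CC1` gives 84.4%, with a number 5.1 percentage points higher from compound 1 to compound 2 (within the scatter). Compound 3 `Nc1ccccc1NC(=O)c1ccc(CSC(=S)N2CCN(c3ncccn3)CC2)cc1` gives 64.8%, the lowest of the three numbers: the step was a number 14.5 percentage points lower from compound 1 to compound 3 (beyond the scatter), and a number 19.6 percentage points lower from compound 2 to compound 3 (beyond the scatter).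

Compound 4 `Nc1ccccc1NC(=O)c1ccc(CSC(=S)N2CCN(c3ccncc3)CC2)cc1` is the next compound to be measured in this assay. It differs from compound 3 in one place: pyridin-4-yl in place of pyrimidin-2-yl on an amine nitrogen in a ring. Among the measured compounds shown here, no measured step shows this exact exchange. The two steps that come closest are the ones that put pyrimidin-2-yl onto the amine nitrogen in the ring, namely a number 14.5 percentage points lower from compound 1 to compound 3 (beyond the scatter) and a number 19.6 percentage points lower from compound 2 to compound 3 (beyond the scatter), and both lowered the number by a modest amount beyond the scatter. Removing pyrimidin-2-yl again, this time for pyridin-4-yl, is therefore expected to move the number back upward, but since no other aryl group directly on that ring nitrogen has been measured, the expected size of the step is uncertain and could also stay within the scatter. The estimated step is a number 7.2 percentage points higher from compound 3 to compound 4 (within the scatter). Compound 4 is expected to give about 72% in this assay, within a range from 56% to 86%.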

Compound 4, a percentage reported as inhibition, at one concentration (the size of the read-out at that concentration, not a potency): 87.1%
Compound 4: middle estimate off by 15.1 percentage points, on the low side; measured number outside the range, above it.
By their numbers in this assay, from the lowest: compound 3; then compounds 1, 2 and 4 (each within the scatter of the next).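

In this assay the exchange of pyrimidin-2-yl, with 2 hetero atoms in its ring, for pyridin-4-yl, with 1 hetero atom, on the amine nitrogen in a ring gives a number 22.3 percentage points higher from compound 3 to compound 4 (beyond the scatter) and shows that the lower number of compound 3 does not extend to every six-membered aromatic ring placed directly on that nitrogen. Pyridin-4-yl on that nitrogen also matches the smaller and the longer substituent, with a number 2.7 percentage points higher from compound 2 to compound 4 (within the scatter) against methyl and a number 7.8 percentage points higher from compound 1 to compound 4 (within the scatter) against (pyridin-4-yl)methyl, so methyl, (pyridin-4-yl)methyl and pyridin-4-yl cannot be told apart at this position, and compound 3 alone goes against that pattern. Nothing given here offers an explanation for the gap between the two aromatic groups.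

The compounds shown leave open whether a phenyl ring or pyridin-2-yl on that nitrogen would give a number like that of compound 4 or like that of compound 3. With a read-out at a single concentration, they also leave open whether compounds that cannot be told apart here would still differ in potency.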